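Replacing 4-Fluorophenyl with (Pyridin-3-yl)methyl on a Ring Amine

A few compounds are considered here, and "the series" means these few. Any claim that something is new, unique, unknown or untested is made for them only; others in the source may bear on it.

Of the compounds shown here, three sharing one core have been measured in a functional assay on HeLa cells (Homo sapiens) for antiproliferative activity, read by CCK-8 assay, with a stated time of 72 h, tested at 8 uM; a lower number here means a weaker effect, a higher number a stronger effect of the compound at the concentration tested. Compound 1 `Nc1ccccc1NC(=O)c1ccc(CSC(=S)N2CCCc3ccccc32)cc1` gives 35.7%, compound 2 `Nc1ccccc1NC(=O)c1ccc(CSC(=S)N2CCN(c3ccc(F)cc3)CC2)cc1` gives 64.5%, and compound 3 `CC1CCN(C(=S)SCc2ccc(C(=O)Nc3ccccc3N)cc2)CC1` gives 72.5%. Compound 2 thus stands second highest of the three: its nearest neighbour is compound 3, whose number lies within the scatter of compound 2, while compound 1 is the furthest, beyond the scatter.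

Compound 4 `Nc1ccccc1NC(=O)c1ccc(CSC(=S)N2CCN(Cc3cccnc3)CC2)cc1` has not yet been measured in this assay. It differs from compound 2 in one place: (pyridin-3-yl)methyl in place of 4-fluorophenyl on an amine nitrogen in a ring. Among the measured compounds shown here, the only measured single-change step, a number 36.8 percentage points higher from compound 1 to compound 3 (beyond the scatter), alters the group on the thiocarbonyl carbon, not the group on the amine nitrogen in a ring, so it does not bear directly on this change. For the measured compounds named here, there is no measured pair in which the group on that ring nitrogen is exchanged, so the direction of the step is not known from the data.

Going by the values given here, with no guiding step, compound 4 is expected to land close to compound 2, and the estimated step of a number 4.5 percentage points lower from compound 2 to compound 4 (within the scatter) is expected to stay within the scatter. The estimate for compound 4 in this assay is 60%, with a range from 42% to 76%.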

Compound 4, a percentage reported as inhibition, at one concentration (the size of the read-out at that concentration, not a potency): 78%
Compound 4: the middle estimate sits 18 percentage points below what was measured; the measured number lies above the stated range.
By their numbers in this assay, from the lowest: compound 1; then compounds 2, 3 and 4 (each within the scatter of the next, the first and the last beyond it).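

In this assay, among the compounds shown here, the exchange of 4-fluorophenyl for (pyridin-3-yl)methyl gives the first measured step at this amine nitrogen in a ring, a number 13.5 percentage points higher from compound 2 to compound 4 (beyond the scatter), which shows that the group held there can shift the read-out by more than the usual scatter. Both groups have 7 heavy atoms, yet the entering one differs in three ways: it loses the fluorine, its aromatic ring holds a hetero atom and a hydrogen-bond acceptor, and it is attached through a methyl link rather than directly. The step therefore shows that this combined change raises the number in this one pair, while nothing measured here accounts for the rise.

The compounds shown leave open which of those three differences carries the step, and a benzyl group on the same nitrogen would help separate the effect of the ring's hetero atom from that of the methyl link. They also leave open how a much smaller group, such as a plain methyl or an acetyl, would read at this position.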